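Changing one aromatic group on compound 2

The source may hold more compounds than are shown below. What is called first, only, known or untested is meant among the compounds shown, and "the series" means these compounds.

- compound 1 `O=C(CN1CCN(c2nnc(Cc3ccccc3)c3ccccc23)CC1)Nc1c(F)cccc1F`: 5490 nM
- compound 2 `O=C(CN1CCN(c2nnc(Cc3ccncc3)c3ccccc23)CC1)Nc1cccc(F)c1`: 4.4 nM
- compound 3 `O=C(CN1CCN(c2nnc(Cc3ccccc3)c3ccccc23)CC1)Nc1cccc(F)c1`: 3730 nM
- compound 4 `Cc1ccccc1NC(=O)CN1CCN(c2nnc(Cc3ccncc3)c3ccccc23)CC1`: not yet measured

All values come from a functional assay on MDA-MB-231 cells (Homo sapiens) for cytotoxicity, read by MTT assay, with a stated time of 72 h; on this read-out higher numbers stand for weaker inhibition and lower numbers for stronger inhibition. Compound 2 has the lowest number of the three, well beyond the scatter from both others.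

Compound 4 differs from compound 2 in one place: 2-methylphenyl in place of 3-fluorophenyl on an amide-type nitrogen. In short, 2-methylphenyl stands in place of 3-fluorophenyl on an amide-type nitrogen.

The closest evidence is a swap at that same place, a 1.5-fold lower number from compound 1 to compound 3 (0.17 log units; within the scatter). However, that pair carries phenyl rather than pyridin-4-yl, and neither it nor any other measured compound contains 2-methylphenyl. The much larger an 850-fold higher number from compound 2 to compound 3 (2.93 log units; beyond the scatter) comes from a change elsewhere, so it does not apply directly, though it shows how far numbers can move in this small set.

Little change beyond the scatter is therefore expected in this assay. The expected result is a 1.8-fold higher number from compound 2 to compound 4 (0.26 log units; within the scatter), with a wide margin toward higher numbers. For compound 4 the estimated value is 8 nM, with an expected range from 1.5 nM to 60 nM.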

Compound 4, half-maximal inhibitory concentration: 200 nM
Estimate against measurement, compound 4: 25-fold (1.40 log units) below; the measured number lies above the stated range.
By their numbers in this assay, from the lowest: compound 2; then compound 4; then compounds 3 and 1 (each within the scatter of the next).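

In this assay, for the compounds shown here, the group on the amide-type nitrogen clearly matters: changing only that group gives a 45-fold higher number from compound 2 to compound 4 (1.66 log units; beyond the scatter). The earlier swap at this place, a 1.5-fold lower number from compound 1 to compound 3 (0.17 log units; within the scatter), stayed within the scatter, but it involved different groups and carried phenyl rather than pyridin-4-yl, so this place can respond strongly to at least some changes. The size of the new step does not follow from simple counts, as 3-fluorophenyl and 2-methylphenyl have the same number of heavy atoms and hydrogen-bond donors and acceptors.

No measurement shown here explains the step. The two groups differ in both the substituent and its numbered place, and a comparison with 3-methylphenyl or 2-fluorophenyl on the amide-type nitrogen could separate these two differences.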